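The source may hold more compounds than are shown below. What is called first, only, known or untested is meant among the compounds shown, and "the series" means these compounds.

Measured so far:
- compound 1 `COc1cccc(Nc2nccc(-c3ccncc3)n2)c1`: 400 nM
- compound 2 `Cc1cc(-c2ccncc2)nc(Nc2cccc(N(C)C)c2)n1`: > 24000 nM

In a functional assay for inhibition, with Homo sapiens as the target (a higher number here means a weaker inhibitor, a lower number a stronger inhibitor), compound 1 gives 400 nM. For compound 2 this assay reports only a limit, > 24000 nM, and so compound 2 sits at the edge of what the assay resolves (the limit of > 24000 nM in this assay, at which 1 of the 2 values shown sits); no number is known for it. Compound 3 `COc1cccc(Nc2nc(C)cc(-c3ccncc3)n2)c1` is not yet measured. It differs from compound 2 in one place: methoxy in place of dimethylamino on an aromatic carbon. Compound 1 also carries a methoxy on that ring and gives 400 nM. Compound 2, which carries the dimethylamino together with the methyl on the core, is at the limit. Which of these two features accounts for the limit cannot be told from the two values. The step from compound 2 to compound 3 is expected to go toward a stronger inhibitor, of size an at least 8.0-fold lower number from compound 2 to compound 3 (0.90 log units; beyond the scatter). Compound 3 is therefore expected at 3000 nM, within 400 nM to 24000 nM.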

Compound 3, half-maximal inhibitory concentration: > 24000 nM
Compound 3 was reported as a limit; the forecaster's own chance of this, stated with the estimate: 25%; at least 8.0-fold (0.90 log units) between middle value and limit.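

The methyl on the core now stands apart from the dimethylamino, which the earlier two compounds could not show. With the methoxy kept, methyl in place of hydrogen on an aromatic carbon gives in this assay an at least 60-fold higher number from compound 1 to compound 3 (1.77 log units; beyond the scatter), so the methyl alone is enough to reach the limit, with no dimethylamino present. Compound 2 and compound 3 are both reported only as limits, not numbers, so the step between them cannot be read and the exchange of methoxy for dimethylamino stays undetermined: the limit of > 24000 nM in this assay, at which 2 of the 3 values shown sit.

Open, on these data alone, is whether dimethylamino on the core of compound 1, without the methyl, gives a number in this assay. Also open, as far as these compounds go, is whether a fluorine or a chlorine in place of the methyl on the core stays clear of the limit.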